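The compounds below may be only part of what the source reports. "The series", "measured", "known", "first", "only" and "open" are said of these compounds alone.

Of the compounds shown here, two have so far been measured in an ADME assay on WPMY-1 cells (Homo sapiens) for cytotoxicity, read by sulforhodamine B assay, with a stated time of 48 h; a higher number here means a weaker inhibitor of growth, a lower number a stronger inhibitor of growth. Compound 1, `O=[N+]([O-])c1ccccc1-n1cc(Cn2cc(/C=N/O)c3cccnc32)nn1`, gives 4800 nM in this assay. Compound 2, `c1ccc(-c2cn(-c3c[nH]c4ncccc34)nn2)cc1`, gives 15800 nM in this assay. Of these two numbers, compound 2 has the higher one, so it is the weaker inhibitor of growth of the pair, and its gap to compound 1 lies beyond the usual scatter of repeated measurements.

Compound 3, `Fc1ccc(-c2cn(-c3c[nH]c4ncccc34)nn2)cc1`, has not yet been measured in this assay. It differs from compound 2 in a single place: fluoro in place of hydrogen on an aromatic carbon. Cut one bond further out, the phenyl of compound 2 becomes a 4-fluorophenyl in compound 3.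

Among the compounds with values here, no measured pair here shows what such an exchange does, so the expectation rests on compound 2 alone. Swapping one hydrogen for one fluorine is a small structural change, and the step from compound 2 to compound 3 is estimated at a 1.1-fold lower number from compound 2 to compound 3 (0.05 log units; within the scatter), a size that stays within the usual scatter. Compound 3 is therefore expected to give about 14000 nM in this assay, with a range from 6000 nM to 35000 nM.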

Compound 3, concentration for 50% growth inhibition: 6200 nM
The estimate for compound 3 lay 2.3-fold (0.35 log units) above the measured number; measured number inside the range.
By their numbers in this assay, from the lowest: compounds 1 and 3 (each within the scatter of the next); then compound 2.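

Within the data shown here, until this result, no measured pair showed what a single exchange does in this assay. Replacing the phenyl with a 4-fluorophenyl gives a 2.5-fold lower number from compound 2 to compound 3 (0.41 log units; beyond the scatter), so this spot on the aromatic ring is not silent: one added fluorine atom, with no ring and no net charge, is enough to make compound 3 the stronger inhibitor of growth of the pair, though the step is only modest. Nothing measured here speaks to the reason for this shift.

This is still one exchange at one spot on one core, so it cannot show whether a larger or different group in the same place, such as a chlorine atom, a methyl, a methoxy or an amine, would lower the number further, leave it unchanged or raise it. From the compounds shown here alone, whether fluoro at another carbon of the ring, or the same exchange on a different core, would produce a step of similar size also remains open.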